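This account rests on a few compounds, and the source may have more. Where it says the series, first, only, none or still open, it means among the compounds named here.

Measured compounds:
- compound 1 `COc1cc(C(=O)N2CCCC2)ccc1-c1ccnc2[nH]c(C3CCOCC3)cc12`: 0.8 L/kg
- compound 2 `COc1cc(F)ccc1-c1ccnc2[nH]c(C3CCN(CC(=O)N(C)C)CC3)cc12`: 2.3 L/kg
- compound 3 `CC(C)n1cc(-c2ccnc3[nH]c(C4CCN(CC(=O)N5CCCCC5)CC4)cc23)ccc1=O`: 8.1 L/kg

In an ADME assay (Rattus norvegicus, strain Han-wistar) for pharmacokinetics, at a dose of 1.5 umol/kg by the intravenous route (a lower number here means that more of the compound stays in the plasma, a higher number that more of the compound sits outside the plasma), compound 3 stands highest of the three; its gap to compound 2 lies beyond the scatter, and the gap to compound 1 is wider still.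

Compound 4 `CC(C)n1cc(-c2ccnc3[nH]c(C4CCN(CC(=O)N5CCCC5)CC4)cc23)ccc1=O` is not yet measured. It differs from compound 3 in one place: pyrrolidin-1-yl in place of piperidin-1-yl on a carbonyl carbon

For the measured compounds named here, no measured pair in this set shows what this change does. Since the two rings are of like kind and the change lies far from the core, the expected step of a 1.2-fold lower number from compound 3 to compound 4 (0.10 log units; within the scatter) is small and downward at most, not clearly beyond the scatter. Compound 4 is therefore estimated at 6.5 L/kg in this assay, with a range from 3.5 L/kg to 12 L/kg.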

Compound 4, volume of distribution in the Rattus norvegicus assay: 3.9 L/kg
The estimate for compound 4 lay 1.7-fold (0.22 log units) above the measured number, within the range that was stated.
By their numbers in the Rattus norvegicus assay, from the lowest: compound 1; then compounds 2 and 4 (each within the scatter of the next); then compound 3.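

In the Rattus norvegicus assay, the group on this carbonyl carbon is not silent: pyrrolidin-1-yl in place of piperidin-1-yl gives a 2.1-fold lower number from compound 3 to compound 4 (0.32 log units; beyond the scatter). In a physicochemical assay for acid dissociation, compound 3 gives 7.8 and compound 4 gives 7.8, so this change shows no change at the digits printed from compound 3 to compound 4 (within the scatter) in that read-out. Nothing measured here accounts for the step in the Rattus norvegicus assay.

From the compounds shown here alone, whether azetidin-1-yl or morpholin-4-yl on the same carbonyl carbon would extend this step remains open. So does the size of this change on the cores of compound 1 and compound 2.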